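Styryl sulfone series: from compound 2 to compound 3

The source may report more compounds than this note shows. Statements on the series, on what has been measured and on what is new or still open speak of the compounds shown alone.

Measured in a functional assay on MCF7 cells (Homo sapiens); a lower number here means a stronger inhibitor of growth, a higher number a weaker inhibitor of growth:
- compound 1 `O=S(=O)(/C=C/c1ccc(Cl)cc1)Cc1ccc(Nc2ncnc3ccc(Br)cc23)cc1`: 46000 nM
- compound 2 `O=S(=O)(/C=C/c1ccc(Cl)cc1Cl)Cc1ccc(Nc2ncnc3ccc(Br)cc23)cc1`: 4000 nM

Of the two numbers in this assay, the lower belongs to compound 2 at 4000 nM. Compound 3 `O=S(=O)(/C=C/c1ccc(C(F)(F)F)cc1F)Cc1ccc(Nc2ncnc3ccc(Br)cc23)cc1` is the next to be read. The change is 2-fluoro-4-(trifluoromethyl)phenyl in place of 2,4-dichlorophenyl on a double-bonded chain carbon bound to a double-bonded chain carbon, with 2-fluoro-4-(trifluoromethyl)phenyl in place of 2,4-dichlorophenyl on a double-bonded chain carbon bound to a double-bonded chain carbon. Among the compounds with values here, the only measured step that bears on this is a 12-fold lower number from compound 1 to compound 2 (1.06 log units; beyond the scatter), a large one, with chloro in place of hydrogen on an aromatic carbon. Within the data shown here, no measured compound carries fluoro or trifluoromethyl, so that step gives no direction for this exchange, and no shift beyond the scatter is expected. The expected step is a 1.3-fold higher number from compound 2 to compound 3 (0.10 log units; within the scatter). For compound 3 the estimate is 5000 nM, with an expected range of 1500 nM to 20000 nM.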

Compound 3, concentration for 50% growth inhibition: 32000 nM
Compound 3: the middle estimate sits 6.4-fold (0.81 log units) below what was measured; measured number outside the range, above it.
By their numbers in this assay, from the lowest: compound 2; then compounds 3 and 1 (each within the scatter of the next).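

On the double-bonded chain carbon, the exchange of 2,4-dichlorophenyl for 2-fluoro-4-(trifluoromethyl)phenyl in this assay is not neutral: it gives an 8.0-fold higher number from compound 2 to compound 3 (0.90 log units; beyond the scatter) and thus does not keep the low number of compound 2. Set against 4-chlorophenyl, the same entering group gives a 1.4-fold lower number from compound 1 to compound 3 (0.16 log units; within the scatter) and leaves compound 3 level with compound 1, so among these three aryl groups only 2,4-dichlorophenyl stands apart. No measurement at hand accounts for this difference between the groups.

Still open, as far as these compounds go, is which part of the entering group, the fluoro or the trifluoromethyl, goes with the step from compound 2. Also open, from the compounds shown here alone, is how a phenyl ring carrying an amine or a carboxylic acid would read on this chain carbon.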